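Chloro on the cinnamoyl phenyl: from compound 1 to compound 3

The compounds below may be only part of what the source reports. "The series", "measured", "known", "first", "only" and "open" are said of these compounds alone.

Measured so far:
compound 1 `Cc1cc(Nc2ccc(C(=O)/C=C/c3ccccc3)cc2)n2nc(SCc3nc4ccccc4[nH]3)nc2n1`: 130 nM
compound 2 `Cc1cc(Nc2ccc(C(=O)/C=C/c3ccccc3Cl)cc2)n2nc(SCc3nc4ccccc4[nH]3)nc2n1`: 680 nM

Going by the values given here, in a functional assay on SW-620 cells (Homo sapiens) for cytotoxicity, read by MTT assay, with stated times of 4 h and 72 h, tested at 2 uM (on this read-out higher numbers stand for weaker inhibition and lower numbers for stronger inhibition), compound 1 stands with the lowest of the two numbers; the only measured step is a 5.2-fold higher number from compound 1 to compound 2 (0.72 log units; beyond the scatter), which puts a chloro on the same six-membered aromatic ring of carbon only. Compound 3 `Cc1cc(Nc2ccc(C(=O)/C=C/c3cccc(Cl)c3)cc2)n2nc(SCc3nc4ccccc4[nH]3)nc2n1` differs from compound 1 by chloro in place of hydrogen on an aromatic carbon. That single step bears on it and was modest, so a weakening beyond the scatter, though smaller, is expected here. Compound 3 is expected at 260 nM (range 110 nM to 700 nM), an estimated step of a 2.0-fold higher number from compound 1 to compound 3 (0.30 log units; within the scatter).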

Compound 3, half-maximal inhibitory concentration: 400 nM
The estimate for compound 3 lay 1.5-fold (0.19 log units) below the measured number; the range from low to high includes it.
By their numbers in this assay, from the lowest: compound 1; then compounds 3 and 2 (each within the scatter of the next).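

In this assay, the higher number is not confined to 2-chlorophenyl: 3-chlorophenyl also gives a step beyond the scatter (a 3.1-fold higher number from compound 1 to compound 3 (0.49 log units; beyond the scatter)). Changing 2-chlorophenyl to 3-chlorophenyl does not separate the two chloro compounds (a 1.7-fold lower number from compound 2 to compound 3 (0.23 log units; within the scatter)), a step within the scatter. Nothing available explains the effect of chloro on this phenyl.

As far as these compounds go, whether a fluoro, a methoxy or an amine on this phenyl would also raise the number remains open. So does whether any group here could give a lower number than compound 1.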